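From Nitro to Fluoro in Compound 3

This account rests on a few compounds, and the source may have more. Where it says the series, first, only, none or still open, it means among the compounds named here.

Measured in a functional assay on A549 cells (Homo sapiens) for antiproliferative activity, read by sulforhodamine B assay, with a stated time of 48 h; on this read-out lower numbers stand for stronger inhibition and higher numbers for weaker inhibition:
- compound 1 `COc1ccc(C(=O)/C=C\Nc2ccc(-c3nc4cc(OC)c(OC)c(OC)c4s3)cc2C)cc1F`: 1690 nM
- compound 2 `COc1ccc(C(=O)/C=C\Nc2ccc(-c3nc4cc(OC)c(OC)c(OC)c4s3)cc2)cc1O`: 23000 nM
- compound 3 `COc1ccc(C(=O)/C=C\Nc2ccc(-c3nc4cc(OC)c(OC)c(OC)c4s3)cc2)cc1[N+](=O)[O-]`: 21200 nM

Compound 3 stands level with compound 2, within the scatter, and both show higher numbers than compound 1. Compound 4 `COc1ccc(C(=O)/C=C\Nc2ccc(-c3nc4cc(OC)c(OC)c(OC)c4s3)cc2)cc1F` follows from compound 3 by one change, (fluoro in place of nitro on an aromatic carbon), fluoro in place of nitro on an aromatic carbon. Among the measured compounds shown here, the one measured step at this place, a 1.1-fold lower number from compound 2 to compound 3 (0.04 log units; within the scatter), exchanges nitro for hydroxy and does not involve fluoro. The closest guide is compound 1 at 1690 nM, which carries the same 3-fluoro-4-methoxyphenyl but differs from compound 4 elsewhere. A move to a lower number is therefore expected, a 3.5-fold lower number from compound 3 to compound 4 (0.55 log units; beyond the scatter). For compound 4 the estimate is 6000 nM, with an expected range of 1700 nM to 21000 nM.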

Compound 4, half-maximal inhibitory concentration: 15500 nM
Beside the measured number, compound 4's estimate is 2.6-fold (0.41 log units) below it, and the stated range covers the measured number.
By their numbers in this assay, from the lowest: compound 1; then compounds 4, 3 and 2 (each within the scatter of the next).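

In this assay, fluoro at this place, ortho to a methoxy group, stays level with both nitro (a 1.4-fold lower number from compound 3 to compound 4 (0.14 log units; within the scatter)) and hydroxy (a 1.5-fold lower number from compound 2 to compound 4 (0.17 log units; within the scatter)), so among these three groups the number does not depend on which one sits here. With fluoro held fixed, the step beyond the scatter comes from the other place, hydrogen in place of methyl (a 9.2-fold higher number from compound 1 to compound 4 (0.96 log units; beyond the scatter)), so the low number of compound 1 goes with its methyl and not with its fluoro. Going by these compounds, whether an amine at the fluoro position would also stay level, and whether methyl would give a similar step alongside nitro or hydroxy, remains open. Nothing available explains why these numbers fall as they do.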